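This account rests on a few compounds, and the source may have more. Where it says the series, first, only, none or still open, it means among the compounds named here.

Working notes on the series, read in an ADME assay on Karpas-1106P cells (Homo sapiens) for cytotoxicity; a higher number here means that more compound is needed for the effect, a lower number that less compound is needed. Compound 1 `COc1cc(OC)cc(C(=O)NCCNC(=O)[C@H](CC(=O)NC(C)(C)C)NS(=O)(=O)c2ccc(C)cc2)c1` gives > 11100 nM, which is a limit of the assay. Compound 2 `Cc1ccc(S(=O)(=O)N[C@@H](CC(=O)NC(C)(C)C)C(=O)NCCNS(=O)(=O)c2ccccc2)cc1` gives > 11100 nM, again a limit and not a number. The picture so far is the limit of > 11100 nM in this assay, at which 2 of the 2 values shown sit, so compound 2 offers no numerical starting point.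

Compound 3 `C#Cc1cccc(C(=O)NCCNC(=O)[C@H](CC(=O)NC(C)(C)C)NS(=O)(=O)c2ccc(C)cc2)c1` keeps the rest of compound 2 and changes one group, on an amine nitrogen: a group of 10 heavy atoms (9 carbon, 1 oxygen; one six-membered aromatic ring of carbon only) in place of a group of 9 heavy atoms (6 carbon, 2 oxygen, 1 sulfur; one six-membered aromatic ring of carbon only), on an amine nitrogen. Among the measured compounds shown here, the only measured step bearing on this change, a step that the two limits leave unreadable from compound 1 to compound 2, exchanges groups on the same amine nitrogen. It has no readable size and gives no direction. On that step alone, no change beyond the usual scatter is expected, and compound 3 is expected most likely to report a limit as well.

For compound 3 the estimated value is 11100 nM, with an expected range from 4000 nM to 25000 nM. The expected change, a number no higher from compound 2 to compound 3 (the limit leaves the size open), is an estimate set against a limit and carries no firm direction.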

Compound 3, half-maximal effective concentration: > 11100 nM
Compound 3 ended at the assay's limit; the forecaster's own chance of this, stated with the estimate: 75%; the middle value sits exactly at the limit.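

In this assay compound 3 gives > 11100 nM, a limit of the assay and not a number. Among the compounds shown here, no step among compound 1, compound 2 and compound 3 can be read: the limit of > 11100 nM in this assay, at which 3 of the 3 values shown sit. The compounds shown leave open what size and direction any exchange of groups on the amine nitrogen would have in a measurable range.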